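The source may report more compounds than this note shows. Statements on the series, on what has been measured and on what is new or still open speak of the compounds shown alone.

Measured so far:

Compound 1, `Cc1ccc2c(c1)-c1cnc(n1C)OCCCCCCCCO2`: 34000 nM
Compound 2, `COc1ccc2c(c1)-c1cnc(n1C)OCCCCCCCCO2`: 32000 nM
Compound 3, `C=CCCCCOc1ccc(C)cc1-c1cnc(OCCC=C)n1C`: 53000 nM

All three were tested in a functional assay on MCF7 cells (Homo sapiens) for inhibition, read by colorimetric assay and MTT assay, with a stated time of 72 h; a higher number here means a weaker inhibitor, a lower number a stronger inhibitor. Compound 1 and compound 2 share one core and differ in a single place: methoxy in place of methyl on an aromatic carbon That change gave a 1.1-fold lower number from compound 1 to compound 2 (0.03 log units; within the scatter), so the two compounds cannot be told apart by this assay.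

Compound 3 is built on a different core, and the difference between the two cores is not broken down here. In this assay compound 3 gives 53000 nM, and its values against compound 1 and compound 2 lie within the usual scatter, so no order among the three can be claimed.

Compound 4, `C=CCCCCOc1ccc(OC)cc1-c1cnc(OCCC=C)n1C`, has not yet been measured. Among the measured compounds shown here, it differs from compound 3 in one place: methoxy in place of methyl on an aromatic carbon This is the same kind of change as the one from compound 1 to compound 2, but the surroundings differ: in compound 1 the place is part of a fused or bridged system of three rings, meta to a fused ring and para to a fused ring, whereas in compound 3 it is meta to a large group and para to a (hex-5-en-1-yl)oxy group.

The step of a 1.1-fold lower number from compound 3 to compound 4 (0.03 log units; within the scatter) is expected to be small because the earlier step of a 1.1-fold lower number from compound 1 to compound 2 (0.03 log units; within the scatter) stayed within the scatter. Compound 4 is therefore estimated to give about 50000 nM in this assay. The estimate for compound 4 is expected to fall between 25000 nM and 100000 nM.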

Compound 4, half-maximal inhibitory concentration: 37000 nM
For compound 4 the middle estimate is 1.4-fold (0.13 log units) above the measured one; the range from low to high includes it.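

In this assay, putting methoxy in place of methyl on the aromatic carbon gave a 1.4-fold lower number from compound 3 to compound 4 (0.16 log units; within the scatter), so on this second core the change again leaves the two compounds indistinguishable. Set side by side, the two steps agree as far as this measurement can tell: the same change on two cores in this assay, a 1.1-fold lower number (0.03 log units; within the scatter) from compound 1 to compound 2 and a 1.4-fold lower number (0.16 log units; within the scatter) from compound 3 to compound 4, 1.3-fold (0.13 log units) apart, within the scatter of two such steps. This shows that the swap carries from the core of compound 1 to the core of compound 3 without any detectable shift in its outcome, but both steps are too small to be read, so the agreement is only that neither one registers; it does not show that the two cores would respond alike to a change with a clear effect, and it says nothing about why these steps are so small.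

The compounds shown carry only methyl or methoxy at this place, which leaves open what an amine, a carboxylic acid or a longer alkoxy chain there would do in this assay. They also leave open whether the same swap on another aromatic carbon of either core would give a step that could be told from the scatter.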